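Swapping a fluorophenyl for a methylphenyl on a shared core

This account rests on a few compounds, and the source may have more. Where it says the series, first, only, none or still open, it means among the compounds named here.

Of the compounds shown here, three built on the same core have been measured in a functional assay on A549 cells (Homo sapiens) for antiproliferative activity, read by CCK-8 assay, with a stated time of 48 h; on this read-out higher numbers stand for weaker inhibition and lower numbers for stronger inhibition. Compound 1 `COc1cc(-c2nnc(-n3[se]c4ccccc4c3=O)s2)cc(OC)c1OC` gives 3240 nM, compound 2 `COc1ccc(-c2nnc(-n3[se]c4ccccc4c3=O)s2)cc1` gives 5930 nM, and compound 3 `O=c1c2ccccc2[se]n1-c1nnc(-c2ccc(F)cc2)s1` gives 21100 nM. Compound 3 thus stands with the highest number of the three; its nearest neighbour is compound 2, and compound 1 lies furthest from it. Within the data shown here, the one step measured between compounds differing in a single place is a 3.6-fold higher number from compound 2 to compound 3 (0.55 log units; beyond the scatter).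

Compound 4 `Cc1ccccc1-c1nnc(-n2[se]c3ccccc3c2=O)s1` differs from compound 3 by 2-methylphenyl in place of 4-fluorophenyl on an aromatic carbon. Among the measured compounds shown here, no measured step bears directly on this change: the only step on record, the one from compound 2 to compound 3, exchanges a methoxy for a fluoro and is not the same exchange. On that basis the number for compound 4 is expected to stay within a modest distance of compound 3, in no clear direction, and an estimated 1.4-fold lower number from compound 3 to compound 4 (0.15 log units; within the scatter) is the most that can be said. Compound 4 is therefore estimated at 15000 nM in this assay, within a range of 5000 nM to 45000 nM.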

Compound 4, half-maximal inhibitory concentration: 18600 nM
Beside the measured number, compound 4's estimate is 1.2-fold (0.09 log units) below it; the range from low to high includes it.
By their numbers in this assay, from the lowest: compounds 1 and 2 (each within the scatter of the next); then compounds 4 and 3 (each within the scatter of the next).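

In this assay, putting 2-methylphenyl in place of 4-fluorophenyl gives a 1.1-fold lower number from compound 3 to compound 4 (0.05 log units; within the scatter) and so leaves the number effectively unchanged, even though the swap alters both the group on the phenyl ring and its printed location. Among these compounds, this position is not indifferent to every change, since the earlier exchange of methoxy for fluoro gave a 3.6-fold higher number from compound 2 to compound 3 (0.55 log units; beyond the scatter) and this new step shows only that these two particular groups cannot be told apart on this read-out. No measurement on hand speaks to why they match.

The compounds shown leave open how an unsubstituted phenyl, or a phenyl carrying an amine or a carboxylic acid, would compare at this position. As far as these compounds go, it also remains open whether the match between these two groups would hold in another cell line.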